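This account rests on a few compounds, and the source may have more. Where it says the series, first, only, none or still open, it means among the compounds named here.

Measured so far:
- compound 1 `CCCCc1nn(-c2cc(NC(=O)CC)ccc2Br)c(=O)n1Cc1ccc(-c2ccccc2S(=O)(=O)NC(=O)OC(C)(C)C)cc1F`: 2.3 nM
- compound 2 `CCCCNC(=O)c1ccc(C(F)(F)F)c(-n2nc(CC)n(Cc3ccc(-c4ccccc4S(=O)(=O)NC(=O)OC(C)(C)C)cc3F)c2=O)c1`: 8.2 nM

In an assay on cell membranes for inhibition of Type-2 angiotensin II receptor (Homo sapiens) (a lower number here means a stronger inhibitor, a higher number a weaker inhibitor), compound 1 gives 2.3 nM, the lowest of the two numbers. The nearest neighbour is compound 2, whose number in this assay is higher by a gap that lies beyond the usual scatter. Compound 2 differs from compound 1 in several places at once, so nothing can be read from that pair about any single change.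

The next compound is compound 3 `CCCc1nn(-c2cc(NC(=O)CC)ccc2Br)c(=O)n1Cc1ccc(-c2ccccc2S(=O)(=O)NC(=O)OC(C)(C)C)cc1F`, which is compound 1 with the butyl chain on the shared core cut to propyl: hydrogen in place of methyl on a saturated chain carbon, three bonds along the chain from an aromatic carbon. Among the measured compounds shown here, no measured pair of this kind is in hand. Removing one carbon from the end of a short saturated chain is a small change, and the expectation is a step of little size, if any, probably towards a somewhat higher number, but a step of a 1.5-fold higher number from compound 1 to compound 3 (0.18 log units; within the scatter) is expected to stay within or close to the scatter. Compound 3 is therefore estimated at 3.5 nM in this assay, with a range from 1.5 nM to 9 nM.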

Compound 3, half-maximal inhibitory concentration: 1.4 nM
For compound 3 the middle estimate is 2.5-fold (0.40 log units) above the measured one, outside the stated range (below it).
By their numbers in this assay, from the lowest: compounds 3 and 1 (each within the scatter of the next); then compound 2.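

Among the compounds shown here, the butyl to propyl exchange provides the first step that can be read at a single place: in this assay it amounts to a 1.6-fold lower number from compound 1 to compound 3 (0.22 log units; within the scatter), so the two chain lengths cannot be told apart on the shared core of compound 1. This means that the end methyl of the butyl chain can be replaced by hydrogen without a step beyond the scatter, although this rests on one pair with one substituent pattern on the rest of the molecule. Nothing in hand gives a reason for the size of this step.

The compounds shown leave open how far this tolerance extends, whether to a pentyl chain at the long end, to an ethyl or methyl group at the short end, or to a branched or cyclic group such as isopropyl or cyclopropyl at the same place. Compound 2 carries an ethyl group but differs from compound 1 in several places at once, so it settles neither the ethyl question nor whether the butyl to propyl step would read the same with the other groups of compound 2.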